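Formyl to 2-Benzoylethenyl at the Limit of the Assay

The compounds below may be only part of what the source reports. "The series", "measured", "known", "first", "only" and "open" are said of these compounds alone.

Of the compounds shown here, three have been measured so far in a functional assay on Jurkat cells (Homo sapiens) for cytotoxicity, with a stated time of 72 h; a lower number here means that less compound is needed, a higher number that more compound is needed for the effect. Compound 1 (`C=C[C@@](C)(/C=C/c1ccc(OC)cc1)CCC=C(C)C`) gives > 49000 nM as a limit of the assay and not a number. Compound 2 (`C=C[C@@](C)(/C=C/c1ccc(O)cc1)CC/C=C(\C)CO`) gives > 49000 nM as a limit too. Compound 3 (`COc1ccc(/C=C/[C@@](C)(/C=C/c2ccc(O)c(C=O)c2)CCC=C(C)C)cc1`) gives > 49000 nM as a limit as well. Within the data shown here, compound 3 therefore has no exact number, and the series so far shows only the limit of > 49000 nM in this assay, at which 3 of the 3 values shown sit, with nothing to rank the compounds.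

Compound 4 (`COc1ccc(/C=C/[C@@](C)(/C=C/c2ccc(O)c(/C=C/C(=O)c3ccccc3)c2)CCC=C(C)C)cc1`) carries 2-benzoylethenyl in place of formyl on an aromatic carbon ortho to a hydroxy group. Among the measured compounds shown here, no measured step guides this change. The expected step of an at least 2.2-fold lower number from compound 3 to compound 4 (0.34 log units; beyond the scatter) is moderate and points towards less compound being needed, although a reading that stays at the limit is also expected to be quite possible. In this assay the estimated value for compound 4 is 22000 nM with an expected range from 6000 nM to 49000 nM at this stage.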

Compound 4, half-maximal effective concentration: > 49000 nM
Compound 4 gave a limit, no number; the forecaster's own chance of this, stated with the estimate: 45%; middle value at least 2.2-fold (0.34 log units) away from the limit.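

Compound 3 and compound 4 both sit at a limit of the assay rather than at a number, so no step can be read between them: the limit of > 49000 nM in this assay, at which 4 of the 4 values shown sit.

The compounds shown leave open how any of the four rank in this assay, and whether any change to the shared core would give an exact number.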